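Moving the hydroxyl around the ring on the sulfonyl sulfur

This account rests on a few compounds, and the source may have more. Where it says the series, first, only, none or still open, it means among the compounds named here.

Compound 1 `COc1cccc(S(=O)(=O)Nc2ccc3oc(-c4ccccc4)nc3c2)c1` gives > 100000 nM in an assay on cells for inhibition of HSP60/HSP10 (Homo sapiens), with a stated time of 60 min (on this read-out higher numbers stand for weaker inhibition and lower numbers for stronger inhibition), which is a limit of the assay and not a number. Compound 2 `O=S(=O)(Nc1ccc2oc(-c3ccccc3)nc2c1)c1ccccc1F` likewise gives > 100000 nM in this assay, again a limit. Among the compounds with values here, compound 3 `O=S(=O)(Nc1ccc2oc(-c3ccccc3)nc2c1)c1cccc(O)c1` gives 76000 nM in this assay, the only number among the three.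

Compound 3 therefore stands alone with a measured value, while the other two sit at the limit of > 100000 nM in this assay, at which 2 of the 3 values shown sit. Compound 4 `O=S(=O)(Nc1ccc2oc(-c3ccccc3)nc2c1)c1ccc(O)cc1` differs from compound 3 by 4-hydroxyphenyl in place of 3-hydroxyphenyl on a sulfonyl sulfur.

Within the data shown here, two measured steps bear on this change, both leading into compound 3 from a limit: an at least 1.3-fold lower number from compound 1 to compound 3 (0.11 log units; that floor lies within the scatter) and an at least 1.3-fold lower number from compound 2 to compound 3 (0.11 log units; that floor lies within the scatter). Neither compares two positions of the same hydroxyl, and each only sets a floor that lies within the scatter. Nothing measured here separates a 3-hydroxyphenyl from a 4-hydroxyphenyl on the sulfonyl sulfur, so no step beyond the scatter is expected in this assay, with a fair chance that only a limit is reported.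

Compound 4 is estimated at 95000 nM, within 40000 nM to 250000 nM, which means an expected step of a 1.3-fold higher number from compound 3 to compound 4 (0.10 log units; within the scatter).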

Compound 4, half-maximal inhibitory concentration: 88000 nM
Estimate against measurement, compound 4: 1.1-fold (0.03 log units) above, within the range that was stated.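

The change from 3-hydroxyphenyl to 4-hydroxyphenyl on a sulfonyl sulfur appears in this assay as a 1.2-fold higher number from compound 3 to compound 4 (0.06 log units; within the scatter). Within the data shown here, this is the first direct comparison of two positions of the same hydroxyl, and the read-out does not tell them apart. Against the other two compounds, the steps are an at least 1.1-fold lower number from compound 2 to compound 4 (0.05 log units; that floor lies within the scatter) and an at least 1.1-fold lower number from compound 1 to compound 4 (0.05 log units; that floor lies within the scatter), so these floors show no gain for 4-hydroxyphenyl over 2-fluorophenyl or 3-methoxyphenyl beyond the scatter, and compound 1 and compound 2 remain limits of the assay and not numbers: the limit of > 100000 nM in this assay, at which 2 of the 4 values shown sit.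

As far as these compounds go, it remains open whether an amine or a carboxylic acid in place of the hydroxyl would give a step beyond the scatter. The compounds shown also leave open whether any group at this place can do so.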